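Butylcarbamoyl for fluoro on the indole-free bicycle: compound 4

This account rests on a few compounds, and the source may have more. Where it says the series, first, only, none or still open, it means among the compounds named here.

Three compounds have numbers in a functional assay on K562 cells (Homo sapiens) for antiproliferative activity, read by CCK-8 assay, with a stated time of 72 h; a higher number here means a weaker inhibitor of growth, a lower number a stronger inhibitor of growth. Compound 1 `CC[C@@H]1C(=O)N(C)c2cnc(-n3ccc4cc(F)ccc43)nc2N1C1CCCC1` gives 21200 nM, the highest of the three. Compound 2 `CCC1C(=O)N(C)c2cnc(-n3ccc4cc(C(=O)NCC(C)C)ccc43)nc2N1c1ccn(C)n1` gives 5600 nM, and compound 3 `CCCCNC(=O)c1ccc2c(ccn2-c2ncc3c(n2)N(c2ccn(C)n2)C(CC)C(=O)N3C)c1` gives 14100 nM; the gap from compound 1 to compound 3 lies within the scatter, while compound 2 sits beyond it. Among the measured compounds shown here, the one single-point step available, a 2.5-fold higher number from compound 2 to compound 3 (0.40 log units; beyond the scatter), concerns the chain on the amide nitrogen, not the change now in question.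

Compound 4 `CCCCNC(=O)c1ccc2c(ccn2-c2ncc3c(n2)N(C2CCCC2)[C@H](CC)C(=O)N3C)c1` differs from compound 1 by butylcarbamoyl in place of fluoro on an aromatic carbon. For the measured compounds named here, no measured pair isolates this change. Compound 3 carries the same butylcarbamoyl group but a different substituent on the ring nitrogen of the core, so its number against compound 1 is only indirect evidence, and that pair lies within the scatter. The expected step is therefore a 1.8-fold lower number from compound 1 to compound 4 (0.25 log units; within the scatter), a small move toward a lower number that is not expected to go clearly beyond the scatter. Compound 4 is expected to give about 12000 nM in this assay, within a range of 4000 nM to 36000 nM.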

Compound 4, concentration for 50% growth inhibition: 673 nM
Compound 4: middle estimate off by 18-fold (1.25 log units), on the high side; measured number outside the range, below it.
By their numbers in this assay, from the lowest: compound 4; then compound 2; then compounds 3 and 1 (each within the scatter of the next).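

In this assay, butylcarbamoyl in place of fluoro on this aromatic carbon gives a 32-fold lower number from compound 1 to compound 4 (1.50 log units; beyond the scatter), a large step toward stronger inhibition of growth. Among the compounds shown here, this is the first direct reading of the change, as the only earlier step concerned the chain on the amide nitrogen. The position, on the six-membered aromatic ring of carbon only, accepts the larger group with a clear gain, but nothing at hand bears on what lies behind this step.

Which part of butylcarbamoyl carries the gain stays open, as does whether a carboxylic acid, a shorter amide chain or a chain ending in an amine at this carbon would keep it. Also open, going by these compounds, is whether the same exchange gives a step of this size with another substituent on the ring nitrogen of the core.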